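The source may report more compounds than this note shows. Statements on the series, on what has been measured and on what is new or still open speak of the compounds shown alone.

Measured so far in an assay on CHO cells for agonist activity at Neuronal acetylcholine receptor; alpha3/alpha6/beta2/beta3 (Homo sapiens), read by FLIPR and calcium flux; a lower number here means that less compound is needed, a higher number that more compound is needed for the effect:
compound 1, `CC(C)C(=O)N1CC2CC(C1)N2`, gives 16000 nM
compound 2, `O=C([C@H]1C[C@@H]1F)N1CC2CC(C1)N2`, gives 620 nM

Compound 2 stands at the lower of the two numbers in this assay; its nearest neighbour is compound 1, and the gap between them is large, as the step of a 26-fold lower number from compound 1 to compound 2 (1.41 log units; beyond the scatter) shows, which is well beyond the scatter of the measurement. That step was a swap on the carbonyl carbon, with 2-fluorocyclopropyl in place of isopropyl.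

Compound 3, `C[C@@H]1C[C@@H]1C(=O)N1CC2CC(C1)N2`, is the next member of the series and has not yet been measured. It differs from compound 2 in one place: a group of 4 heavy atoms (4 carbon; one three-membered non-aromatic ring of carbon only) in place of a group of 4 heavy atoms (3 carbon, 1 fluorine; one three-membered non-aromatic ring of carbon only), on a carbonyl carbon. The three-membered ring on the carbonyl carbon is kept, but the fluorine on it is exchanged for a carbon.

Among the compounds with values here, the only measured step that bears on this change is the one from compound 1 to compound 2, and it was large. Compound 3 keeps part of what was introduced in that step and gives up another part, so for compound 3 a step of a 2.4-fold higher number from compound 2 to compound 3 (0.38 log units; beyond the scatter) in this assay is expected, that is a modest rise in the number that may still fall within the scatter. Compound 3 is therefore estimated at 1500 nM, with a likely range from 400 nM to 6000 nM.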

Compound 3, half-maximal effective concentration: 920 nM
Compound 3: the middle estimate sits 1.6-fold (0.21 log units) above what was measured, and the stated range covers the measured number.
By their numbers in this assay, from the lowest: compounds 2 and 3 (each within the scatter of the next); then compound 1.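

In this assay, the fluorine on the three-membered ring turns out not to be required: exchanging it for a carbon on the carbonyl carbon gives a 1.5-fold higher number from compound 2 to compound 3 (0.17 log units; within the scatter) and leaves the two groups indistinguishable in this measurement. Compound 2 alone could not show whether its large difference from compound 1 depended on the ring or on the fluorine, but the listed change to the fluorine-free ring gives a 17-fold lower number from compound 1 to compound 3 (1.24 log units; beyond the scatter), so the lower number goes with the three-membered ring in both compounds, whichever of the two atoms it carries. Nothing available explains why this ring is tied to a lower number than the open isopropyl group.

From the compounds shown here alone, what a bare cyclopropyl group, with only hydrogen on the ring, would give remains open, as does the effect of a larger ring such as cyclobutyl, a longer chain such as ethyl on the ring, or an amine in that place. Also open, going by these compounds, is whether the spatial arrangement at the two defined stereocentres matters, which only the other stereoisomers of these ring groups could show.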